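This account rests on a few compounds, and the source may have more. Where it says the series, first, only, none or still open, it means among the compounds named here.

Measured so far in a functional assay on L1210 cells (Mus musculus) for cytotoxicity, read by MTT assay, with a stated time of 72 h; on this read-out higher numbers stand for weaker inhibition and lower numbers for stronger inhibition:
- compound 1, `CCCCCCCCC(=O)c1cc(O)c(O)c(O)c1`: 22000 nM
- compound 2, `CCCCCCCCCCC(=O)c1cc(O)c(O)c(O)c1`: 15500 nM

Compound 2 gives the lower of the two numbers, but the step of a 1.4-fold lower number from compound 1 to compound 2 (0.15 log units; within the scatter) lies within the scatter, so the two compounds are not separated. Compound 3, `CCCCCCCCCCCC(=O)c1cc(O)c(O)c(O)c1`, differs from compound 2 by methyl in place of hydrogen on a saturated chain carbon, ten or more bonds along the chain from a carbonyl carbon. Going by the values given here, the only bearing step is the chain extension from compound 1 to compound 2, which stayed within the scatter; the same is therefore expected for the entering methyl, with an estimated step of a 1.2-fold lower number from compound 2 to compound 3 (0.08 log units; within the scatter) in this assay. Compound 3 is estimated at 13000 nM, between 6000 nM and 30000 nM.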

Compound 3, half-maximal inhibitory concentration: 8120 nM
Estimate against measurement, compound 3: 1.6-fold (0.20 log units) above; measured number inside the range.
By their numbers in this assay, from the lowest: compounds 3, 2 and 1 (each within the scatter of the next, the first and the last beyond it).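

In this assay the single added methyl gives a 1.9-fold lower number from compound 2 to compound 3 (0.28 log units; within the scatter) and so separates nothing on its own. Over the whole chain extension, however, propyl in place of hydrogen gives a 2.7-fold lower number from compound 1 to compound 3 (0.43 log units; beyond the scatter) and this is the first separation in the series, a modest one, with compound 3 set apart from compound 1 only. No evidence on the cause of this step is at hand.

From the compounds shown here alone, what a longer chain would give remains open, as does whether an amine in place of the entering methyl would keep this step.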